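A few compounds are considered here, and "the series" means these few. Any claim that something is new, unique, unknown or untested is made for them only; others in the source may bear on it.

In a physicochemical assay for solubility (on this read-out lower numbers stand for lower solubility and higher numbers for higher solubility), compound 1 `CNC(=O)c1cc(C(=O)NC2CC2)cc2c1OC[C@H]2c1cccc2[nH]ccc12` reads >= 142 ug/mL and that reading is a limit. Compound 2 `CNC(=O)c1cc(C(=O)N[C@H]2[C@@H]3COC[C@@H]32)cc2c1OC[C@H]2c1cccc2[nH]ccc12` reads >= 171 ug/mL and this too is a limit, so compound 2 has no exact place on the scale. Compound 3 `CNC(=O)c1cc(C(N)=O)cc2c1O[C@H](CF)[C@H]2c1ccccc1` reads >= 128 ug/mL and this is also a limit. Among the measured compounds shown here, the series so far therefore holds no exact number.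

For the measured compounds named here, the only measured step is a step that the two limits leave unreadable from compound 1 to compound 2 and it concerns the group on an amide-type nitrogen, so it gives no size to carry forward. Compound 4 `CNC(=O)c1cc(C(=O)N[C@H]2[C@@H]3COC[C@@H]32)cc2c1OC[C@H]2c1ccc(F)cc1` keeps that group of compound 2 and changes another place: 4-fluorophenyl in place of 1H-indol-4-yl on a saturated ring carbon with 4-fluorophenyl in place of 1H-indol-4-yl on a saturated ring carbon. Going by the values given here, no measured step covers this change. The nearest guide is compound 3, which also lacks the 1H-indol-4-yl group and still gives the limit >= 128 ug/mL in this assay as its reading.

No step beyond the scatter is therefore expected, and the data give no direction. The expected change is an at least 1.1-fold lower number from compound 2 to compound 4 (0.05 log units; that floor lies within the scatter) and this estimate stays within the scatter. Compound 4 is estimated at 150 ug/mL with an expected range from 70 ug/mL to 220 ug/mL and a good chance that the reading is again only a limit.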

Compound 4, solubility: >= 176 ug/mL
Compound 4: only a limit was reported; the forecaster's own chance of this, stated with the estimate: 65%; middle value at least 1.1-fold (0.06 log units) from the limit.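

In this assay compound 4 gives >= 176 ug/mL, and this is a limit. Compound 2 gives >= 171 ug/mL, also a limit, so no step can be read between compound 2 and compound 4. The compounds shown leave open whether 4-fluorophenyl in place of 1H-indol-4-yl on a saturated ring carbon changes the reading at all, and in which direction.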